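Cyclopropyl for cyclobutyl on the ether oxygen

The source may hold more compounds than are shown below. What is called first, only, known or untested is meant among the compounds shown, and "the series" means these compounds.

compound 1 `CCOc1cc(-c2ccc3[nH]ccc3c2)cn2c(-c3cc(OC)c(OC)c(OC)c3)nnc12`: 166 nM
compound 2 `COc1cc(-c2nnc3c(OC4CCC4)cc(-c4ccc5[nH]ccc5c4)cn23)cc(OC)c1OC`: 142 nM
compound 3 `COc1cc(-c2nnc3c(OC4CC4)cc(-c4ccc5[nH]ccc5c4)cn23)cc(OC)c1OC`: not yet measured

All values come from a functional assay on HeLa cells (Homo sapiens) for antiproliferative activity, read by MTT assay, with a stated time of 48 h (on this read-out lower numbers stand for stronger inhibition and higher numbers for weaker inhibition), and compound 2 sits within the scatter of compound 1. Compound 3 differs from compound 2 as follows: cyclopropyl in place of cyclobutyl on an oxygen on an aromatic ring with cyclopropyl in place of cyclobutyl on an oxygen on an aromatic ring. Among the measured compounds shown here, one measured step bears on this, a 1.2-fold lower number from compound 1 to compound 2 (0.07 log units; within the scatter) on exchanging ethyl for cyclobutyl on that oxygen. The expected result is a 1.1-fold higher number from compound 2 to compound 3 (0.02 log units; within the scatter) and thus no step beyond the scatter. Compound 3 is estimated at 150 nM (range 85 nM to 280 nM).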

Compound 3, half-maximal inhibitory concentration: 119 nM
For compound 3 the middle estimate is 1.3-fold (0.10 log units) above the measured one; measured number inside the range.
By their numbers in this assay, from the lowest: compounds 3, 2 and 1 (each within the scatter of the next).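

In this assay, cyclopropyl on the oxygen gives a 1.2-fold lower number from compound 2 to compound 3 (0.08 log units; within the scatter) and, set against ethyl, gives a 1.4-fold lower number from compound 1 to compound 3 (0.14 log units; within the scatter) as well. With a three-membered ring added, ethyl, cyclobutyl and cyclopropyl cannot be told apart at this place, so ring size here has no readable effect across these three compounds. Nothing on hand accounts for this flat response.

Still open, as far as these compounds go, is whether a longer chain, an amine or a carboxylic acid on that oxygen would move the number beyond the scatter. The compounds shown also leave open whether hydrogen on that oxygen would do so.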